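The source may hold more compounds than are shown below. What is called first, only, known or untested is meant among the compounds shown, and "the series" means these compounds.

Measured compounds in an ADME assay on A549 cells (Homo sapiens) for cytotoxicity, read by CellTiter-Glo; a higher number here means that more compound is tolerated, a lower number that less compound is tolerated:
- compound 1 `Cc1c(Cc2ccc(F)cc2)c(=O)oc2cc(OCC(O)CN3CCC(C(N)=O)CC3)ccc12`: 89300 nM
- compound 2 `Cc1c(Cc2ccc(Br)cc2)c(=O)oc2cc(OCC(O)CN3CCC(C(N)=O)CC3)ccc12`: in this assay compound 2 reaches only the limit of the assay, > 100000 nM
- compound 3 `Cc1cc(F)ccc1Cc1c(C)c2ccc(OCC(O)CN3CCC(C(N)=O)CC3)cc2oc1=O`: in this assay compound 3 likewise reaches only the limit, > 100000 nM

Compound 3 thus stands at the limit rather than at a number; two of the three values sit there (the limit of > 100000 nM in this assay, at which 2 of the 3 values shown sit). The step of an at least 1.1-fold higher number from compound 1 to compound 3 (0.04 log units; that floor lies within the scatter) has a floor that lies within the scatter, as does an at least 1.1-fold higher number from compound 1 to compound 2 (0.04 log units; that floor lies within the scatter); the step that the two limits leave unreadable from compound 2 to compound 3 cannot be read because both ends are limits.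

Compound 4 `COc1ccc(Cc2c(C)c3ccc(OCC(O)CN4CCC(C(N)=O)CC4)cc3oc2=O)c(Br)c1` differs from compound 3 by 2-bromo-4-methoxyphenyl in place of 4-fluoro-2-methylphenyl on a saturated chain carbon bound to an aromatic carbon. The nearest comparison is the exchange of halogens on the same ring, an at least 1.1-fold higher number from compound 1 to compound 2 (0.04 log units; that floor lies within the scatter), which gave no readable movement beyond the scatter, and the methyl change an at least 1.1-fold higher number from compound 1 to compound 3 (0.04 log units; that floor lies within the scatter), equally flat. Within this series no step has moved this assay beyond the scatter, so for compound 4 an estimated step of a number no higher from compound 3 to compound 4 (the limit leaves the size open) of no size beyond the scatter is expected, most likely ending again at the limit. Compound 4 is therefore estimated at 100000 nM, with a range from 50000 nM to 200000 nM.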

Compound 4, half-maximal cytotoxic concentration: 44400 nM
Estimate against measurement, compound 4: 2.3-fold (0.35 log units) above; the measured number lies below the stated range.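

Within the data shown here, at this place, on a saturated chain carbon bound to an aromatic carbon, 2-bromo-4-methoxyphenyl is the first exchange to move this assay beyond the scatter, with an at least 2.2-fold lower number from compound 3 to compound 4 (0.35 log units; beyond the scatter) and an at least 2.2-fold lower number from compound 2 to compound 4 (0.35 log units; beyond the scatter). Among these compounds, compound 2 and compound 3 each stand at a limit rather than at a number, so both steps are floors and their full size stays unread: the limit of > 100000 nM in this assay, at which 2 of the 4 values shown sit. Against the one measured number among the earlier compounds, the same exchange gives a 2.0-fold lower number from compound 1 to compound 4 (0.30 log units; within the scatter), so 2-bromo-4-methoxyphenyl is not separated from 4-fluorophenyl here.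

As far as these compounds go, the bromo and methoxy groups enter together, so it remains open whether 2-bromophenyl or 4-methoxyphenyl alone would go with the lower number. Also open, from the compounds shown here alone, is how this assay would read with an amine or a carboxylic acid in place of the methoxy group.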